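Amide variant of compound 1: expected paw edema inhibition

The compounds below may be only part of what the source reports. "The series", "measured", "known", "first", "only" and "open" are said of these compounds alone.

Notes on a three-member series sharing one core, with a fourth compound awaiting measurement. Compound 1 `N#CC1=C(NCN2CCCC2)N(c2ccccc2)C(=O)N2CCCCC(N3CCCC3)C12` carries a (pyrrolidin-1-yl)methylamino arm; compound 2 `N#CC1=C(NCC(=O)O)N(c2ccccc2)C(=O)N2CCCCC(N3CCCC3)C12` has carboxy in place of pyrrolidin-1-yl on that arm; compound 3 `N#CC1=C(/N=C/Nc2ccc([N+](=O)[O-])cc2)N(c2ccccc2)C(=O)N2CCCCC(N3CCCC3)C12` bears a larger arm on the double-bonded ring carbon. In a functional assay on the whole organism (strain albino) for inhibition, with Rattus norvegicus as the target, read by paw edema, with stated times of 1 h and 3 h, at a dose of 20 mmol/kg by the intraperitoneal route (a lower number here means a weaker effect, a higher number a stronger effect of the compound at the dose given), compound 1 gives 35.3%, compound 2 gives 89.2% and compound 3 gives 85.6%. Compound 1 stands lowest of the three, and both other compounds lie beyond the scatter above it: a number 53.9 percentage points higher from compound 1 to compound 2 (beyond the scatter) and a number 50.3 percentage points higher from compound 1 to compound 3 (beyond the scatter), while a number 3.6 percentage points lower from compound 2 to compound 3 (within the scatter).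

Compound 4 `N#CC1=C(NCC(=O)N2CCCC2)N(c2ccccc2)C(=O)N2CCCCC(N3CCCC3)C12` differs from compound 1 as follows: (pyrrolidin-1-yl)carbonyl in place of pyrrolidin-1-yl on a saturated chain carbon bound to an amine nitrogen. Among the compounds with values here, the step that bears most directly on this is the one to compound 2, where the same position on the arm was changed and the step was large, a number 53.9 percentage points higher from compound 1 to compound 2 (beyond the scatter). Compound 4 carries a carbonyl at that position but not the carboxy of compound 2, so a rise from compound 1 is expected, of uncertain size; the estimate here is a number 24.7 percentage points higher from compound 1 to compound 4 (beyond the scatter). The expected value for compound 4 is 60%, in the range 38% to 85%.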

Compound 4, a percentage reported as inhibition, in the whole organism at one dose (the size of the read-out at that dose, not a potency): 56%
For compound 4 the middle estimate is 4 percentage points above the measured one; low and high end bracket the measured number.
By their numbers in this assay, from the lowest: compound 1; then compound 4; then compounds 3 and 2 (each within the scatter of the next).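

Read in this assay, (pyrrolidin-1-yl)carbonyl in place of pyrrolidin-1-yl on the saturated chain carbon bound to an amine nitrogen gives a number 20.7 percentage points higher from compound 1 to compound 4 (beyond the scatter) and shows that this position can tolerate a carbonyl with the pyrrolidine ring still attached, with a gain in the read-out. The group on that carbonyl carbon also matters: pyrrolidin-1-yl in place of hydroxy gives a number 33.2 percentage points lower from compound 2 to compound 4 (beyond the scatter) and so accounts for a large part of the difference in this series, and the carbonyl alone does not carry compound 4 to the level of compound 2. The whole arm on the double-bonded ring carbon can be compared as well, and a number 29.6 percentage points lower from compound 3 to compound 4 (beyond the scatter) places compound 4 clearly under the larger nitrophenyl-bearing arm, so compound 4 sits in the middle of the series.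

Still open, from the compounds shown here alone, is whether a dimethylamino group or a simple primary amide on the same carbonyl carbon would stay with compound 4 or move toward compound 2, and whether a methyl ester or a longer chain carrying the carboxylic acid would behave as compound 2 does. No measurement is available that explains any of these steps.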